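The source may report more compounds than this note shows. Statements on the series, on what has been measured and on what is new or still open speak of the compounds shown alone.

Measured so far:
compound 1 `CC(C)C[C@H](N)c1cc(C(F)(F)F)ccc1N1CCN(C(=O)C(C)Cc2ccc(Cl)cc2)CC1` — 47 nM
compound 2 `Cc1ccc(OCC(=O)N2CCN(c3ccc(C(F)(F)F)cc3[C@@H](N)CC(C)C)CC2)cc1` — 4400 nM
compound 3 `CC(C)C[C@H](N)c1cc(F)ccc1N1CCN(C(=O)C(C)Cc2ccc(Cl)cc2)CC1` — 390 nM

All three were tested in an assay on HEK293 cells for displacement of a labelled ligand from Melanocortin receptor 4 (Homo sapiens); on this read-out higher numbers stand for weaker inhibition and lower numbers for stronger inhibition. Compound 1 gives the lowest number of the three; compound 3 is nearest, with an 8.3-fold higher number from compound 1 to compound 3 (0.92 log units; beyond the scatter), and compound 2 lies furthest away, with a 94-fold higher number from compound 1 to compound 2 (1.97 log units; beyond the scatter).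

Compound 4 `Cc1ccc(OCC(=O)N2CCN(c3ccc(C(F)(F)F)cc3[C@@H](N)CC(C)C)CC2)c(C)c1` has not yet been measured. It differs from compound 1 in one place: (2,4-dimethylphenoxy)methyl in place of 1-(4-chlorobenzyl)ethyl on a carbonyl carbon. The change sits on the same carbonyl carbon as the change from compound 1 to compound 2, and the group that enters, (2,4-dimethylphenoxy)methyl, is close in kind to the (4-methylphenoxy)methyl of compound 2, carrying one more methyl on its aromatic ring. The step from compound 1 to compound 3 concerns a different position and does not bear on this change.

Among the measured compounds shown here, the one step that does bear on it, the step from compound 1 to compound 2, was large and went toward weaker inhibition. A step of similar size and direction is therefore expected here, with the extra methyl leaving some room on either side: for compound 4 in this assay the expected step is a 74-fold higher number from compound 1 to compound 4 (1.87 log units; beyond the scatter), and the expected value is 3500 nM (range 900 nM to 14000 nM).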

Compound 4, inhibition constant: 4000 nM
The estimate for compound 4 lay 1.1-fold (0.06 log units) below the measured number; low and high end bracket the measured number.
By their numbers in this assay, from the lowest: compound 1; then compound 3; then compounds 4 and 2 (each within the scatter of the next).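

In this assay, a second (phenoxy)methyl-type group on the carbonyl carbon gives an 85-fold higher number from compound 1 to compound 4 (1.93 log units; beyond the scatter), so the large step seen with compound 2 is not a result confined to that single group. The extra methyl on the aromatic ring gives a 1.1-fold lower number from compound 2 to compound 4 (0.04 log units; within the scatter), which means this read-out cannot tell compound 2 and compound 4 apart, and adding this methyl neither recovers the stronger inhibition of compound 1 nor moves the number further from it. No measurement shown here explains why these groups give so much weaker inhibition than the 1-(4-chlorobenzyl)ethyl group.

Both exchanges alter several features at once, including the oxygen in the chain, the chloro on the ring and the branching methyl, so the compounds shown leave open which of these matters most. A (4-chlorophenoxy)methyl group would separate the ring chloro from the oxygen, while a 2-(4-chlorophenyl)ethyl group would keep the chloro and carry neither the oxygen nor the branching methyl.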